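Methyl to Trifluoromethyl on the Amide-Bound Ring

The compounds below may be only part of what the source reports. "The series", "measured", "known", "first", "only" and "open" are said of these compounds alone.

Two measured compounds share one core and differ only in the ring hanging from the amide nitrogen. Compound 1 `Cc1ccccc1CNC(=O)/C=C/c1ccc(O)c(O)c1` gives 25% in an ADME assay on B16 cells (Mus musculus) for cytotoxicity, read by MTT assay, tested at 10 uM (a lower number here means a weaker effect, a higher number a stronger effect of the compound at the concentration tested), while compound 2 `Cc1ccc(CNC(=O)/C=C/c2ccc(O)c(O)c2)cc1` gives 20% in this assay, a step of a number 5 percentage points lower from compound 1 to compound 2 (within the scatter). Compound 2 thus stands at the lower of the two numbers, yet within the scatter of compound 1. Compound 3 `O=C(/C=C/c1ccc(O)c(O)c1)NCc1ccc(C(F)(F)F)cc1` brings (trifluoromethyl in place of methyl on an aromatic carbon). Going by the values given here, the only measured step stayed within the scatter and offers little guidance, so no change beyond the scatter is expected; the estimate means a step of a number 2 percentage points higher from compound 2 to compound 3 (within the scatter). Compound 3 is therefore expected near 22%, with a range from 10% to 38%.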

Compound 3, a percentage reported as activity, at one concentration (the size of the read-out at that concentration, not a potency): 39%
The estimate for compound 3 lay 17 percentage points below the measured number; the whole stated range lies below it.
By their numbers in this assay, from the lowest: compounds 2 and 1 (each within the scatter of the next); then compound 3.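

In this assay, the group on this aromatic carbon does make a difference: trifluoromethyl in place of methyl gives a number 19 percentage points higher from compound 2 to compound 3 (beyond the scatter), whereas the earlier change from 2-methylphenyl to 4-methylphenyl stayed within the scatter. Nothing available here explains the rise.

As far as these compounds go, this remains a single change at a single position, so it is open whether the number is specific to trifluoromethyl. A chlorine atom, a methoxy group or an amine on the same carbon would show how the read-out follows the group placed there.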